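This account rests on a few compounds, and the source may have more. Where it says the series, first, only, none or still open, it means among the compounds named here.

Compound 1 `O=S(=O)(NCCCCCCNCc1ccc(Br)cc1)c1ccccc1Cl` — 13700 nM
Compound 2 `COc1ccc(CNCCCNS(=O)(=O)c2cc(C(F)(F)F)cc(C(F)(F)F)c2)cc1OC` — 2800 nM
Compound 3 `O=S(=O)(NCCCCCCNCc1ccc(Br)cc1)c1ccc2c(c1)OCC2` — 13000 nM

Three compounds have been run in a functional assay on MIA PaCa-2 cells (Homo sapiens) for inhibition, read by MTT assay, with a stated time of 72 h; on this read-out lower numbers stand for stronger inhibition of growth and higher numbers for weaker inhibition of growth. Compound 2 stands lowest of the three; compound 3 is the nearest to it and compound 1 the furthest, both beyond the scatter. Compound 4 `O=S(=O)(NCCCNCC1COc2ccccc2O1)c1cc(C(F)(F)F)cc(C(F)(F)F)c1` has not yet been measured. It differs from compound 2 by 2,3-dihydro-1,4-benzodioxin-2-yl in place of 3,4-dimethoxyphenyl on a saturated chain carbon bound to an amine nitrogen. Going by the values given here, the only measured step, a 1.1-fold lower number from compound 1 to compound 3 (0.02 log units; within the scatter), concerns a group on a sulfonyl sulfur and says nothing direct about a change on the saturated chain carbon bound to an amine nitrogen. Among the compounds with values here, no measured pair shows the present change. The step of a 1.4-fold higher number from compound 2 to compound 4 (0.15 log units; within the scatter) is therefore expected to be small, within the scatter or a little weaker. Compound 4 is accordingly estimated at 4000 nM in this assay, with a range from 1500 nM to 12000 nM.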

Compound 4, concentration for 50% growth inhibition: 2600 nM
Compound 4: middle estimate off by 1.5-fold (0.19 log units), on the high side; measured number inside the range.
By their numbers in this assay, from the lowest: compounds 4 and 2 (each within the scatter of the next); then compounds 3 and 1 (each within the scatter of the next).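

In this assay, going by these compounds alone, the step of a 1.1-fold lower number from compound 2 to compound 4 (0.03 log units; within the scatter) gives the first reading at the saturated chain carbon bound to an amine nitrogen. It shows that 2,3-dihydro-1,4-benzodioxin-2-yl can take the place of 3,4-dimethoxyphenyl without a difference beyond the scatter, although its two oxygens now sit in a six-membered non-aromatic ring. No evidence is available on what lies behind this result. From the compounds shown here alone, it remains open how an unsubstituted phenyl, a pyridine or a carboxylic acid would read at this carbon. Going by these compounds, whether the same exchange would hold on a longer chain, as in compound 1 and compound 3, is also open.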